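Imidazole series: thiophene in place of tolyl at the aryl position

The source may report more compounds than this note shows. Statements on the series, on what has been measured and on what is new or still open speak of the compounds shown alone.

Measured in an assay on microsomes from liver for inhibition of 3-hydroxy-3-methylglutaryl-coenzyme A reductase (Rattus norvegicus); on this read-out higher numbers stand for weaker inhibition and lower numbers for stronger inhibition:
compound 1 `CC[C@H](C)C(=O)O[C@H]1C[C@H](O)C=C2C=C[C@H](C)[C@H](CCC(O)C[C@H](O)CC(=O)O)[C@]21C`: 5 nM
compound 2 `O=C(O)C[C@H](O)C[C@H](O)CCn1c(C(F)(F)F)nc(-c2ccc(F)cc2)c1-c1ccc(F)cc1`: 38 nM
compound 3 `Cc1ccc(-c2nc(C(F)(F)F)n(CC[C@@H](O)C[C@@H](O)CC(=O)O)c2-c2ccc(F)cc2)cc1`: 43 nM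

Of the three numbers in this assay, compound 3 has the highest; its nearest neighbour is compound 2, whose value sits within the scatter of that of compound 3, while compound 1 gives a number beyond the scatter below it. For the measured compounds named here, the only step within the shared core of compounds 2 and 3 is a 1.1-fold higher number from compound 2 to compound 3 (0.05 log units; within the scatter), which shows that swapping one substituent on the aryl ring for another left the read-out essentially unchanged.

Compound 4 `O=C(O)C[C@H](O)C[C@H](O)CCn1c(C(F)(F)F)nc(-c2cccs2)c1-c1ccc(F)cc1` is not yet measured in this assay. It differs from compound 3 in one place: thiophen-2-yl in place of 4-methylphenyl on an aromatic carbon. Going by the values given here, no measured step exchanges the whole aryl ring for a five-membered heteroaryl ring, so the only guide is the aryl-substituent step from compound 2 to compound 3, which was within the scatter. On that basis no step beyond the scatter is expected for compound 4 in this assay, with the expected shift being a 1.1-fold lower number from compound 3 to compound 4 (0.03 log units; within the scatter). The estimate for compound 4 in this assay is therefore 40 nM, expected to fall between 15 nM and 110 nM.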

Compound 4, half-maximal inhibitory concentration: 64 nM
Compound 4: the middle estimate sits 1.6-fold (0.20 log units) below what was measured; the range from low to high includes it.
By their numbers in this assay, from the lowest: compound 1; then compounds 2, 3 and 4 (each within the scatter of the next).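

In this assay, the aromatic carbon next to the ring nitrogen accepts replacement of the whole aryl ring, not only of a substituent on it: thiophen-2-yl in place of 4-methylphenyl gives a 1.5-fold higher number from compound 3 to compound 4 (0.17 log units; within the scatter), and thiophen-2-yl in place of 4-fluorophenyl gives a 1.7-fold higher number from compound 2 to compound 4 (0.23 log units; within the scatter). Compounds 2 and 3 had varied only the substituent on a six-membered aromatic ring of carbon only, whereas compound 4 brings a five-membered aromatic ring with 1 hetero atom, with 5 heavy atoms in place of 7, and both steps still stay within the scatter. No independent evidence bears on why this exchange leaves the read-out within the scatter.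

Going by these compounds, how a non-aromatic group at this position, such as cyclohexyl or a plain methyl, or an aryl ring carrying an amine or a carboxylic acid, would read out in this assay remains open. Also open, on these data alone, is whether thiophen-2-yl would give a similar result on the ring atom that bears a 4-fluorophenyl group.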